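Methyl in place of fluoro: compound 3 to compound 4

A few compounds are considered here, and "the series" means these few. Any claim that something is new, unique, unknown or untested is made for them only; others in the source may bear on it.

In an ADME assay on BJ cells (Homo sapiens) for cytotoxicity, with a stated time of 72 h (on this read-out higher numbers stand for an effect only at larger amounts of compound and lower numbers for an effect already at smaller amounts), the measured compounds read as follows, each value being a limit of the assay:
- compound 1 `CCc1ccc(-c2nc3c(c(C)nn3-c3ccccc3)c(-c3ccccc3[N+](=O)[O-])c2C#N)cc1` gives > 20000 nM (limit)
- compound 2 `CCc1ccc(-c2nc3c(c(C)nn3-c3ccccc3)c(-c3ccccc3Br)c2C#N)cc1` gives > 20000 nM (limit)
- compound 3 `CCc1ccc(-c2nc3c(c(C)nn3-c3ccccc3)c(-c3ccccc3F)c2C#N)cc1` gives > 20000 nM (limit)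

Compound 3 has no number of its own, and its value > 20000 nM is a limit. The whole measured set shares this position, with the limit of > 20000 nM in this assay, at which 3 of the 3 values shown sit, as the only summary it allows.

Compound 4 `CCc1ccc(-c2nc3c(c(C)nn3-c3ccccc3)c(-c3ccccc3C)c2C#N)cc1` carries methyl in place of fluoro on an aromatic carbon, ortho to a large group: methyl in place of fluoro on an aromatic carbon. The measured exchanges of this substituent are a step that the two limits leave unreadable from compound 1 to compound 2, a step that the two limits leave unreadable from compound 1 to compound 3 and a step that the two limits leave unreadable from compound 2 to compound 3. None of them has a size that can be carried over, so no step beyond the scatter is expected in this assay and no direction can be given. The expected change is a number no higher from compound 3 to compound 4 (the limit leaves the size open) and a further report of the limit is the likeliest outcome. For compound 4 the estimate is 20000 nM with an expected range of 12000 nM to 30000 nM and the reading still to come.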

Compound 4, half-maximal effective concentration: > 20000 nM
Compound 4 was reported as a limit; the forecaster's own chance of this, stated with the estimate: 85%; the middle value sits exactly at the limit.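

In this assay compound 4 gives > 20000 nM, which is a limit, and no step can be read between it and compound 1, compound 2 or compound 3. The compounds shown leave open whether these aromatic substituents differ at all, and where any real value lies: the limit of > 20000 nM in this assay, at which 4 of the 4 values shown sit.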